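A Pyrazole-to-Triazole Swap on the Thioether Arm

A few compounds are considered here, and "the series" means these few. Any claim that something is new, unique, unknown or untested is made for them only; others in the source may bear on it.

Compound 1 `N#Cc1c(N)nc(SCc2ccn[nH]2)c(C#N)c1-c1ccc(OCC2CC2)cc1` gives 552 nM in an assay on CHO cells for displacement of a labelled ligand from adenosine receptor A1 (Homo sapiens), read by scintillation counting, with a stated time of 90 min (a higher number here means a weaker inhibitor, a lower number a stronger inhibitor), the lowest of the two numbers at hand. Compound 2 `C=C(C)COc1ccc(-c2c(C#N)c(N)nc(SCC(N)=O)c2C#N)cc1` gives 872 nM in this assay, a gap from compound 1 that stays within the scatter, so the two cannot be ordered. Compound 3 `N#Cc1c(N)nc(SCc2ncn[nH]2)c(C#N)c1-c1ccc(OCC2CC2)cc1` differs from compound 1 by 1H-1,2,4-triazol-5-yl in place of 1H-pyrazol-5-yl on a saturated chain carbon bound to a sulfur. Among the measured compounds shown here, no measured pair shows this change, so its size is unknown. The expected step, from compound 1 to compound 3, is a 1.3-fold higher number from compound 1 to compound 3 (0.10 log units; within the scatter), not beyond the scatter. Compound 3 is estimated at 700 nM, within 250 nM to 2000 nM.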

Compound 3, inhibition constant: 338 nM
The estimate for compound 3 lay 2.1-fold (0.32 log units) above the measured number, and the stated range covers the measured number.
By their numbers in this assay, from the lowest: compounds 3, 1 and 2 (each within the scatter of the next, the first and the last beyond it).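

The swap of 1H-pyrazol-5-yl for 1H-1,2,4-triazol-5-yl on a saturated chain carbon bound to a sulfur reads as a 1.6-fold lower number from compound 1 to compound 3 (0.21 log units; within the scatter) in this assay and stays inside the usual variation. At this position, then, the five-membered aromatic ring can take a third hetero atom and a second hydrogen-bond acceptor without a step beyond the scatter. Nothing measured here speaks to a reason for this result. From the compounds shown here alone, what stays open is whether a carboxylic acid or an amine on that carbon in place of the ring, or a longer chain carrying the 1H-1,2,4-triazol-5-yl, would give a step beyond the scatter.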